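The source may report more compounds than this note shows. Statements on the series, on what has been measured and on what is new or still open speak of the compounds shown alone.

Working notes on the core shared by this small set. Compound 1 `C[C@H](Nc1nc(N)nc(N)c1C#N)c1cc2ccc(F)cn2c(=O)c1-c1ccccc1` is the reference point. In an ADME assay on microsomes from liver (Homo sapiens), read by LC-MS, using NADPH, with a stated time of 30 min, tested at 1 uM (on this read-out lower numbers stand for a less stable compound and higher numbers for a more stable compound), compound 1 gives 87%, which stands second highest of the three numbers, with both neighbours inside the scatter. Compound 2 `C[C@H](Nc1nc(N)ncc1C#N)c1cc2ccc(F)cn2c(=O)c1-c1ccccc1` gives 90% in this assay, and the step of a number 3 percentage points higher from compound 1 to compound 2 (within the scatter). Compound 3 `Cc1cc(F)cc(-c2c([C@H](C)Nc3nc(N)nc(N)c3C#N)cc3ccc(F)cn3c2=O)c1` gives 80% in this assay, and the step of a number 7 percentage points lower from compound 1 to compound 3 (within the scatter). So the two measured steps, one at the amino group and one at the phenyl group, both leave the number where it was.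

Compound 4 `Cc1c([C@H](C)Nc2nc(N)nc(N)c2C#N)c(-c2ccccc2)c(=O)n2cc(F)ccc12` is the next member and has not been measured in this assay. It differs from compound 1 by methyl in place of hydrogen on an aromatic carbon. Going by the values given here, no measured step touches this position of the core, so the only guide is that both measured steps, at other positions, stayed within the scatter. On that basis no step beyond the scatter is expected from compound 1 to compound 4 in this assay, and the expected step is a number 2 percentage points lower from compound 1 to compound 4 (within the scatter). Compound 4 is therefore estimated at 85% in this assay, with a range from 70% to 95%.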

Compound 4, percent of the compound remaining: 80%
For compound 4 the middle estimate is 5 percentage points above the measured one, within the range that was stated.
By their numbers in this assay, from the lowest: compounds 3, 4, 1 and 2 (each within the scatter of the next).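

In this assay, going by these compounds alone, the first reading at this position of the shared core, ortho to a fused ring and ortho to a large group, is a number 7 percentage points lower from compound 1 to compound 4 (within the scatter) on going to methyl in place of hydrogen. The position therefore takes a group of 1 heavy atom with a step inside the scatter, which adds a third site to the amino and phenyl sites, where the steps also stayed within the scatter. Nothing available here explains the size of this step or ties it to any feature of the methyl group.

The compounds shown test this position with methyl alone, so it remains open whether the number would stay in place with a longer chain such as propyl, with an amine such as aminomethyl, or with a carboxylic acid on the same aromatic carbon. Within the data shown here, it is also open whether methyl would give a similar step on the core of compound 2 or together with the 3-fluoro-5-methylphenyl group of compound 3, since each comparison here changes only one place on compound 1.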